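The compounds below may be only part of what the source reports. "The series", "measured", "known", "first", "only" and "open" are said of these compounds alone.

Working notes on the series. Compound 3, `CC(C)c1ccc(-c2nc(SCc3cn(CC(=O)NC(=O)Nc4ccccn4)nn3)nc(Nc3cccc(C(F)(F)F)c3)c2C#N)cc1`, gives 8620 nM in a functional assay on MCF7 cells (Homo sapiens) for inhibition, read by MTT assay, with a stated time of 72 h (a lower number here means a stronger inhibitor, a higher number a weaker inhibitor), the lowest of the two numbers in hand. Compound 2, `CC(C)c1ccc(-c2nc(SCc3cn(CC(=O)NC(=O)Nc4ccccn4)nn3)nc(Nc3cccc(Cl)c3)c2C#N)cc1`, gives 18000 nM in this assay. Compound 1, `CC(C)c1ccc(-c2nc(SCc3cn(CC(=O)NC(=O)Nc4ccccn4)nn3)nc(Nc3ccc(Cl)cc3)c2C#N)cc1`, reaches only the assay limit > 64000 nM in this assay. The measured steps run an at least 3.5-fold lower number from compound 1 to compound 2 (0.55 log units; beyond the scatter), an at least 7.4-fold lower number from compound 1 to compound 3 (0.87 log units; beyond the scatter) and a 2.1-fold lower number from compound 2 to compound 3 (0.32 log units; beyond the scatter). Compound 4, `CC(C)c1ccc(-c2nc(SCc3cn(CC(=O)NC(=O)Nc4ccccn4)nn3)nc(Nc3cccc([N+](=O)[O-])c3)c2C#N)cc1`, differs from compound 3 by nitro in place of trifluoromethyl on an aromatic carbon. Among the compounds with values here, of the measured steps only a 2.1-fold lower number from compound 2 to compound 3 (0.32 log units; beyond the scatter) exchanges one group at that same position, and it was modest; no measured step introduces nitro. The expected step is therefore small, a 1.1-fold higher number from compound 3 to compound 4 (0.04 log units; within the scatter), not clearly beyond the scatter. Compound 4 is estimated at 9500 nM in this assay, within 3000 nM to 30000 nM.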

Compound 4, half-maximal inhibitory concentration: 25900 nM
The estimate for compound 4 lay 2.7-fold (0.44 log units) below the measured number; low and high end bracket the measured number.
By their numbers in this assay, from the lowest: compound 3; then compounds 2 and 4 (each within the scatter of the next). At a limit, above all of these: compound 1.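

Nitro in place of trifluoromethyl gives a 3.0-fold higher number from compound 3 to compound 4 (0.48 log units; beyond the scatter), whereas nitro in place of chloro gives only a 1.4-fold higher number from compound 2 to compound 4 (0.16 log units; within the scatter), so in this assay trifluoromethyl stands apart at this position while nitro and chloro remain unseparated. Against the 4-chlorophenyl compound, 3-nitrophenyl gives an at least 2.4-fold lower number from compound 1 to compound 4 (0.39 log units; beyond the scatter). That step rests on the limit of compound 1, so it is a bound only: the limit of > 64000 nM in this assay, at which 1 of the 4 values shown sits.

The compounds shown give no reason for the gap between trifluoromethyl and nitro. Going by these compounds, whether an amine or a carboxylic acid on this carbon would read with trifluoromethyl or with chloro and nitro stays open.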